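The compounds below may be only part of what the source reports. "The series", "measured", "known", "first", "only" and "open" are said of these compounds alone.

Compound 1, `CCOc1ccc(C(=O)Nc2cc3nc(C4CCCCC4)[nH]c3cc2N(CC)CC)cc1`. In an ADME assay on Vero cells (Chlorocebus sabaeus) for cytotoxicity, read by resazurin assay, with a stated time of 3 days (a higher number here means a weaker inhibitor, a lower number a stronger inhibitor), compound 1 gives > 100 ug/mL, which is a limit of the assay rather than a number.

Compound 2, `C=Cc1cccc(C(=O)Nc2cc3nc(C4CCCCC4)[nH]c3cc2N(CC)CC)c1`. In this assay compound 2 gives > 100 ug/mL, again a limit of the assay and not a number.

Both values shown sit at the limit of > 100 ug/mL in this assay, at which 2 of the 2 values shown sit, so compound 2 stands at the ceiling of what this assay reports, and nothing on the numbers shown separates it from compound 1. Going by the values given here, the one measured step, a step that the two limits leave unreadable from compound 1 to compound 2, cannot be read because both ends are limits.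

Compound 3 is `CCN(CC)c1cc2[nH]c(C3CCCCC3)nc2cc1NC(=O)c1ccc(F)cc1F`. It differs from compound 2 at the carbonyl carbon: 2,4-difluorophenyl in place of 3-vinylphenyl on a carbonyl carbon. Among the compounds with values here, no measured step bears on this change directly; the only step available, a step that the two limits leave unreadable from compound 1 to compound 2, is unreadable and concerns a different pair of groups on the same carbonyl carbon. Since both measured compounds sit at the limit of > 100 ug/mL in this assay, at which 2 of the 2 values shown sit, the expectation for compound 3 is that the step that the limit leaves unreadable from compound 2 to compound 3 stays within the scatter and that the assay again reports a limit. Compound 3 is accordingly estimated at 120 ug/mL in this assay, with a range from 50 ug/mL to 300 ug/mL.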

Compound 3, half-maximal inhibitory concentration: > 100 ug/mL
Compound 3 ended at the assay's limit; the forecaster's own chance of this, stated with the estimate: 75%; the middle value lies beyond the limit too.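

In this assay compound 3 gives > 100 ug/mL, a limit of the assay and not a number. No step among compound 1, compound 2 and compound 3 can be read, so this result adds no new step: the limit of > 100 ug/mL in this assay, at which 3 of the 3 values shown sit.

The compounds shown leave open whether any group on the carbonyl carbon changes the cytotoxicity read-out at all.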